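The source may report more compounds than this note shows. Statements on the series, on what has been measured and on what is new or still open speak of the compounds shown alone.

Notes on the series in an ADME assay on Huh-7 cells (Homo sapiens) for cytotoxicity; a higher number here means that more compound is tolerated, a lower number that less compound is tolerated. Compound 1 `COc1ccc(-n2cc(CNCCN3CCN(C)CC3)c(-c3ccccc3C)n2)cc1` sits at the limit of this assay, > 20000 nM. Compound 2 `Cc1ccccc1-c1nn(-c2ccc(Br)cc2)cc1CNCCN1CCN(C)CC1` gives a number in this assay, 9600 nM. Compound 3 `Cc1ccccc1-c1nn(-c2ccc(F)cc2F)cc1CNCCN1CCN(C)CC1` likewise sits at the limit, > 20000 nM. Among the measured steps, an at least 2.0-fold lower number from compound 1 to compound 2 (0.31 log units; beyond the scatter) is the one read from two values of which one is a number; an at least 2.0-fold higher number from compound 2 to compound 3 (0.31 log units; beyond the scatter) runs into the limit, and a step that the two limits leave unreadable from compound 1 to compound 3. Compound 3 therefore stands at the limit of this assay, where two of the three values sit (the limit of > 20000 nM in this assay, at which 2 of the 3 values shown sit), and only that limit is known for it.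

Compound 4 `CN1CCN(CCNCc2cn(-c3ccc(F)cc3F)nc2C(C)(C)C)CC1` differs from compound 3 by tert-butyl in place of 2-methylphenyl on an aromatic carbon. Going by the values given here, all three measured steps concern the group on the aromatic nitrogen of the five-membered ring; none of them changes the group on the aromatic carbon, so no measured step bears directly on this change, and no step beyond the scatter is expected in this assay. For compound 4 a value of 25000 nM is estimated, within the range 10000 nM to 60000 nM, most probably again reported only as a limit. This estimate means an expected step that the limit leaves unreadable from compound 3 to compound 4.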

Compound 4, half-maximal cytotoxic concentration: > 20000 nM
Compound 4 ended at the assay's limit; the forecaster's own chance of this, stated with the estimate: 70%; the middle value is on the limit's open side.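

Compound 3 and compound 4 both stand at a limit of this assay, not at a number, so no step can be read between them: the limit of > 20000 nM in this assay, at which 3 of the 4 values shown sit.

The compounds shown leave open whether tert-butyl in place of 2-methylphenyl on this aromatic carbon changes the tolerated concentration at all in this assay.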